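A few compounds are considered here, and "the series" means these few. Any claim that something is new, unique, unknown or untested is made for them only; others in the source may bear on it.

In a functional assay on KB-V1 cells (Homo sapiens) for cytotoxicity, read by MTT assay, with a stated time of 72 h (on this read-out lower numbers stand for stronger inhibition and higher numbers for weaker inhibition), three compounds have been measured:
- Compound 1 `CC(C)NC(=S)N/N=C1\C(=O)Nc2ccccc21`: 10300 nM
- Compound 2 `O=C1Nc2ccccc2/C1=N/NC(=S)Nc1cccc(Cl)c1`: 640 nM
- Compound 3 `O=C1Nc2ccccc2/C1=N/NC(=S)Nc1ccc(F)cc1`: 1920 nM

Compound 3 stands in the middle of these three numbers, the second highest. Compound 4 `O=C1Nc2ccccc2/C1=N/NC(=S)Nc1ccc(C(=O)O)cc1` carries carboxy in place of its fluoro on an aromatic carbon: carboxy in place of fluoro on an aromatic carbon. Going by the values given here, no measured step makes this exchange, so the evidence is indirect. Exchanging one aryl group for another gave a 3.0-fold higher number from compound 2 to compound 3 (0.48 log units; beyond the scatter), a modest step. Replacing isopropyl gave a 5.4-fold lower number from compound 1 to compound 3 (0.73 log units; beyond the scatter), also modest. A modest to large step toward a higher number is therefore expected in this assay, though the direction is a judgement the data do not show. The estimated step is a 3.1-fold higher number from compound 3 to compound 4 (0.49 log units; beyond the scatter). Compound 4 is expected at 6000 nM, with an estimated range of 1800 nM to 25000 nM.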

Compound 4, half-maximal inhibitory concentration: > 50000 nM
Compound 4 gave a limit, no number; the forecaster's own chance of this, stated with the estimate: 15%; middle value at least 8.3-fold (0.92 log units) from the limit.
By their numbers in this assay, from the lowest: compound 2; then compound 3; then compound 1. At a limit, above all of these: compound 4.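

In this assay compound 4 gives > 50000 nM as a limit of the assay and not a number. Carboxy in place of fluoro on an aromatic carbon, para to a large group, gave an at least 26-fold higher number from compound 3 to compound 4 (1.41 log units; beyond the scatter) as a large step, whereas the exchange of one aryl group for another had given only the modest 3.0-fold higher number from compound 2 to compound 3 (0.48 log units; beyond the scatter) among the earlier compounds. This single change on the aryl ring thus carries the read-out past every number shown, including that of compound 1 with its isopropyl group.

On these data alone, whether an amine or a methyl ester at this position would raise the number as far remains open. So does the effect of carboxy at the place where compound 2 carries its chloro.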